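This account rests on a few compounds, and the source may have more. Where it says the series, first, only, none or still open, it means among the compounds named here.

Three compounds were measured in a functional assay on the whole organism (strain albino) for inhibition, with Rattus norvegicus as the target, read by paw edema, with a stated time of 1 h, at a dose of 100 mg/kg by the oral route; a higher number here means more inhibition at the dose given (going by the name of the read-out), a lower number less inhibition:

compound 1, `Cn1c(SCC(=O)Nn2c(COc3ccc(Cl)cc3Cl)nc3ccccc3c2=O)nc(-c2ccc(Cl)cc2)c(C#N)c1=O`, gives 76.4%
compound 2, `N#Cc1c(-c2ccc(Cl)cc2)nc(SCC(=O)Nn2c(COc3ccc(Cl)cc3Cl)nc3ccccc3c2=O)n(Cc2ccccc2)c1=O`, gives 72.7%
compound 3, `Cn1c(SCC(=O)Nn2c(COc3ccc(Cl)cc3Cl)nc3ccccc3c2=O)nc(-c2ccc(O)cc2)c(C#N)c1=O`, gives 80%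

Compound 1 and compound 2 share a core and differ only in one change, (phenyl in place of hydrogen on a saturated chain carbon bound to an aromatic nitrogen), and that change made a step of a number 3.7 percentage points lower from compound 1 to compound 2 (within the scatter). Compound 3 differs from compound 1 by a change of its own, (hydroxy in place of chloro on an aromatic carbon), which made a step of a number 3.6 percentage points higher from compound 1 to compound 3 (within the scatter). All three values lie within the usual scatter of one another, so none of them can be set apart from the others.

Compound 4, `N#Cc1c(-c2ccc(O)cc2)nc(SCC(=O)Nn2c(COc3ccc(Cl)cc3Cl)nc3ccccc3c2=O)n(Cc2ccccc2)c1=O`, has not yet been measured. It stands to compound 3 as compound 2 stands to compound 1: the change is phenyl in place of hydrogen on a saturated chain carbon bound to an aromatic nitrogen, at the very same place as before, so it is the same change on a core that differs only as stated above. Since that change gave a step of a number 3.7 percentage points lower from compound 1 to compound 2 (within the scatter) in this assay, the step from compound 3 to compound 4 is expected to be about a number 3 percentage points lower from compound 3 to compound 4 (within the scatter), also within the scatter. Compound 4 is therefore estimated to give about 77%, with a range from 65% to 87%.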

Compound 4, a percentage reported as inhibition, in the whole organism at one dose (the size of the read-out at that dose, not a potency): 54.6%
For compound 4 the middle estimate is 22.4 percentage points above the measured one; the measured number lies below the stated range.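

In this assay the exchange of methyl for benzyl did not carry over from one core to the other, and with the hydroxy group in place it gave a step of a number 25.4 percentage points lower from compound 3 to compound 4 (beyond the scatter): the same change on two cores in this assay, a number 3.7 percentage points lower (within the scatter) from compound 1 to compound 2 and a number 25.4 percentage points lower (beyond the scatter) from compound 3 to compound 4, 21.7 percentage points apart, beyond the scatter of two such steps

Hydroxy in place of chloro also behaved differently on the two cores, and with benzyl in place it gave a step of a number 18.1 percentage points lower from compound 2 to compound 4 (beyond the scatter): the same change on two cores in this assay, a number 3.6 percentage points higher (within the scatter) from compound 1 to compound 3 and a number 18.1 percentage points lower (beyond the scatter) from compound 2 to compound 4, 21.7 percentage points apart, beyond the scatter of two such steps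

Within these four compounds, then, the effect of each change depends on the other, so a step read on one core cannot simply be transferred to the other; this rests on a single pair per core, however, and shows neither why the steps differ nor how the change would behave on any further core.

The compounds shown carry only chloro or hydroxy at the one place and only methyl or benzyl at the other. Going by these compounds, whether an amine or methoxy in place of the hydroxy, or ethyl or a longer chain in place of the benzyl, would follow compound 2 or compound 4 remains open.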